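Aryl change on the shared core: compound 2 to compound 3

A few compounds are considered here, and "the series" means these few. Any claim that something is new, unique, unknown or untested is made for them only; others in the source may bear on it.

- compound 1 `Cc1ncc(C)n2nc(-c3ccn4cc(-c5ccc(F)cc5Cl)nc4n3)nc12`: 11.5 mL.min-1.g-1
- compound 2 `Cc1ncc(C)n2nc(-c3ccn4cc(-c5ccccc5Br)nc4n3)nc12`: 1.8 mL.min-1.g-1

In an ADME assay on microsomes from liver (Rattus norvegicus) for metabolic stability, read by LC-MS, in the presence of a further agent that is not named here (a lower number here means slower removal, a higher number faster removal of the compound), compound 2 has the lower of the two measured numbers, at 1.8 mL.min-1.g-1. The change under consideration leads to the unmeasured compound 3 `Cc1ncc(C)n2nc(-c3ccn4cc(-c5ccc(F)cc5)nc4n3)nc12`: 4-fluorophenyl in place of 2-bromophenyl on an aromatic carbon. In words, 4-fluorophenyl replaces 2-bromophenyl on an aromatic carbon. Among the compounds with values here, one measured step bears on this, a 6.4-fold lower number from compound 1 to compound 2 (0.81 log units; beyond the scatter), and it lies beyond the scatter. Within the data shown here, it is the only evidence, and it also concerns 2-bromophenyl. With compound 1 at 11.5 mL.min-1.g-1 as the only higher reference, removing 2-bromophenyl is expected to raise the number, by somewhat less than that step reduced it. The expected change is a 3.9-fold higher number from compound 2 to compound 3 (0.59 log units; beyond the scatter). For compound 3 the estimated value is 7 mL.min-1.g-1, with an expected range of 2.5 mL.min-1.g-1 to 18 mL.min-1.g-1.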

Compound 3, intrinsic clearance in microsomes: 3.1 mL.min-1.g-1
Beside the measured number, compound 3's estimate is 2.3-fold (0.35 log units) above it; measured number inside the range.
By their numbers in this assay, from the lowest: compounds 2 and 3 (each within the scatter of the next); then compound 1.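

In this assay, 4-fluorophenyl in place of 2-bromophenyl (a 1.7-fold higher number from compound 2 to compound 3 (0.24 log units; within the scatter)) leaves compound 3 within the scatter of compound 2, so a low number on this core does not depend on 2-bromophenyl. Compound 3 also separates the two halogens of compound 1: hydrogen in place of chloro (a 3.7-fold lower number from compound 1 to compound 3 (0.57 log units; beyond the scatter)) is a step beyond the scatter with the 4-fluoro group retained, so the higher number of compound 1 goes with the added chloro and not with the fluoro alone. No measurement bears on why this position responds in this way.

Still open, as far as these compounds go, is whether 2-chlorophenyl, without the fluoro, would read with compound 1 or with compound 2 and compound 3. Also open, from the compounds shown here alone, is how an amine or a carboxylic acid on this aryl ring would read.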